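The compounds below may be only part of what the source reports. "The series", "measured", "known", "first", "only" and "open" are said of these compounds alone.

Of the compounds shown here, two built on a shared core have so far been measured in a functional assay on HEK293 cells for agonist activity at Glucose-dependent insulinotropic receptor (Homo sapiens), read by HTRF and cAMP accumulation, with a stated time of 30 min; on this read-out higher numbers stand for an effect only at larger amounts of compound and lower numbers for an effect already at smaller amounts. Compound 1, `CCc1cnc(N2CCC(n3nnc4cc(-c5ccc(S(C)(=O)=O)cc5)ccc43)CC2)nc1`, gives 31 nM in this assay. Compound 2, `CCNC(=O)c1ccc(-c2cc3nnn(C4CCN(c5ncc(CC)cn5)CC4)c3cn2)c(C)c1`, gives 19 nM in this assay. Compound 2 carries the lower of the two numbers, but its value and that of compound 1 fall within the usual scatter of each other, so the two compounds read as alike on this measure. Compound 3, `CCNC(=O)c1ccc(-c2cc3nnn(C4CCN(c5ncc(CC)cn5)CC4)c3cn2)c(C(F)(F)F)c1`, has not yet been measured. It differs from compound 2 in one place: trifluoromethyl in place of methyl on an aromatic carbon. For the measured compounds named here, no pair of measured compounds here shows what such an exchange does, and the two measured values give no step of that kind to lean on. The step from compound 2 to compound 3 is therefore estimated at a 1.3-fold higher number from compound 2 to compound 3 (0.12 log units; within the scatter), no larger than the scatter and in no settled direction. In this assay compound 3 is expected to give 25 nM, within a range of 8 nM to 80 nM.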

Compound 3, half-maximal effective concentration in the Glucose-dependent insulinotropic receptor assay: 60 nM
Estimate against measurement, compound 3: 2.4-fold (0.38 log units) below; low and high end bracket the measured number.
By their numbers in the Glucose-dependent insulinotropic receptor assay, from the lowest: compounds 2, 1 and 3 (each within the scatter of the next, the first and the last beyond it).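

In the Glucose-dependent insulinotropic receptor assay, the exchange of methyl for trifluoromethyl on this aromatic carbon, ortho to a large group, gives the first step in one place among these compounds, and it is not silent: a 3.2-fold higher number from compound 2 to compound 3 (0.50 log units; beyond the scatter) means that compound 3 needs larger amounts for its effect. For the compounds shown here, in a physicochemical assay for solubility, read by HPLC, in phosphate buffer, measured as thermodynamic solubility, with a stated time of 24 h, at pH 6.8 (on this read-out higher numbers stand for higher solubility and lower numbers for lower solubility), the same exchange goes with higher solubility, so the one change moves the two measures in opposite directions of benefit: the measured solubility of compound 2, < 90 nM, and of compound 3, 1200 nM, an at least 13-fold higher number (1.12 log units; beyond the scatter) In the physicochemical assay, compound 2 gives < 90 nM, which is a limit of the assay and not a number. In the physicochemical assay compound 3 gives 1200 nM as a measured number.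

The compounds shown leave open whether both shifts are particular to trifluoromethyl or would also follow another group on this carbon, such as chlorine, a methoxy group or a nitrile, and whether any such group could keep the potency of compound 2 together with the solubility of compound 3. They also leave open whether the exchange would act in the same way on the core of compound 1, since this single pair sets no general pattern.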